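Replacing the imidazolyl on the benzyl ring: compound 4

The source may hold more compounds than are shown below. What is called first, only, known or untested is meant among the compounds shown, and "the series" means these compounds.

Measured compounds and values in an assay on isolated protein for inhibition of ubiquitin carboxyl-terminal hydrolase 7 (Homo sapiens), with stated times of 30 min and 2 h; a higher number here means a weaker inhibitor, a lower number a stronger inhibitor:
compound 1 `Cn1nc2c(=O)n(CC3(O)CCN(Cc4ccc(-c5ccco5)cc4Cl)CC3)cnc2c1-c1ccc(C2(N)CC2)cc1` gives 66.1 nM
compound 2 `Cn1nc2c(=O)n(CC3(O)CCN(Cc4ccc(-n5ccnc5)cc4Cl)CC3)cnc2c1-c1ccc(CN)cc1` gives 228 nM
compound 3 `CC(=O)NCc1ccc(-c2c3ncn(CC4(O)CCN(Cc5ccc(-c6ccco6)cc5Cl)CC4)c(=O)c3nn2C)cc1` gives 46.1 nM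

Compound 2 stands at the highest number of the three and is thus the weakest inhibitor here; compound 1 and compound 3 each give a lower number, both gaps lying beyond the scatter. Compound 1 and compound 3 differ from each other only at the far aryl end, and that step, a 1.4-fold lower number from compound 1 to compound 3 (0.16 log units; within the scatter), lies within the scatter, so the far aryl end seems not to drive the numbers.

Compound 4 `Cn1nc2c(=O)n(CC3(O)CCN(Cc4ccc(-c5ccsc5Cl)cc4Cl)CC3)cnc2c1-c1ccc(CN)cc1` is compound 2 with 2-chlorothiophen-3-yl in place of 1H-imidazol-1-yl on an aromatic carbon. The change sits on the six-membered aromatic ring of carbon only, meta to a chloro group and para to a large group. Among the measured compounds shown here, no single-point step among the measured compounds covers this position, so the one measured step does not bear on it directly. What the values show is that compound 1 and compound 3, which carry a different group at this position, both give lower numbers than compound 2.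

For compound 4 the number in this assay is therefore expected to fall below that of compound 2, with the step of a 2.5-fold lower number from compound 2 to compound 4 (0.40 log units; beyond the scatter) estimated as a lowering beyond the scatter. The estimate for compound 4 is 90 nM, within 35 nM to 250 nM.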

Compound 4, half-maximal inhibitory concentration: 453 nM
Compound 4: middle estimate off by 5.0-fold (0.70 log units), on the low side; the measured number lies above the stated range.
By their numbers in this assay, from the lowest: compounds 3 and 1 (each within the scatter of the next); then compounds 2 and 4 (each within the scatter of the next).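

In this assay, among the compounds shown here, the first single-place step at this position, on the six-membered aromatic ring of carbon only, meta to a chloro group and para to a large group, reads (a 2.0-fold higher number from compound 2 to compound 4 (0.30 log units; within the scatter)), so exchanging 1H-imidazol-1-yl for 2-chlorothiophen-3-yl does not separate compound 2 from compound 4 in this read-out. The earlier compounds shown here could not show this, as compound 1 and compound 3 each differ from compound 2 in more than one place, and the gaps between them cannot be assigned to this position alone; the new step gives no support for reading those gaps as an effect of the ring at this position. Nothing measured here on the properties of these two groups helps to interpret the step.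

From the compounds shown here alone, whether an amine, a carboxylic acid or a longer chain at this position would give a step beyond the scatter remains open, since both groups compared here are five-membered aromatic rings. For the compounds shown here, also open is what separates compound 2 from compound 1 and compound 3, as no single-place pair links them.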